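This account rests on a few compounds, and the source may have more. Where it says the series, first, only, none or still open, it means among the compounds named here.

Among the measured compounds shown here, the two compounds measured so far set the scene. Compound 1, `CCCC[C@H](O)/C=C\[C@@H]1OC(=O)C=C[C@@H]1OC(C)=O`, in a functional assay on P388 cells (Mus musculus) for cytotoxicity, read by sulforhodamine B assay, with a stated time of 48 h (a higher number here means that more compound is needed for the effect, a lower number that less compound is needed), gives 0.1 ug/mL. Compound 2, `CCCC[C@H](OC(C)=O)[C@@H](OC(C)=O)[C@H](OC(C)=O)[C@H]1CC=CC(=O)O1`, in this assay gives 1 ug/mL, which is the highest of the two numbers, and its nearest neighbour, compound 1, sits beyond the scatter below it. These two are not a single-point pair, so their gap says only what the two values show.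

Compound 3, `CCCC[C@H](OC(C)=O)[C@@H](OC(C)=O)[C@H](OC(C)=O)[C@@H]1OC(=O)C=C[C@@H]1OC(C)=O`, is the next compound. It differs from compound 2 in one place: acetoxy in place of hydrogen on a saturated ring carbon. The entering group is an acetoxy, placed on a saturated ring carbon of the six-membered non-aromatic ring with one oxygen, two ring bonds from the ring oxygen. For the measured compounds named here, compound 1 carries the same acetoxy on the same kind of ring carbon and gives 0.1 ug/mL, whereas compound 2 lacks it and gives 1 ug/mL; this is the only guide available.

For compound 3 the estimated step is a 3.3-fold lower number from compound 2 to compound 3 (0.52 log units; beyond the scatter), a move toward the lower number. The expected value for compound 3 in this assay is 0.3 ug/mL, with a range from 0.08 ug/mL to 1.5 ug/mL.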

Compound 3, concentration for half-maximal effect: 0.4 ug/mL
Beside the measured number, compound 3's estimate is 1.3-fold (0.12 log units) below it; the range from low to high includes it.
By their numbers in this assay, from the lowest: compound 1; then compound 3; then compound 2.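

Among the compounds shown here, the pair compound 2 and compound 3 gives the first reading of a single change: an acetoxy in place of hydrogen on a saturated ring carbon, two ring bonds from the ring oxygen and next to the ring atom that bears a large group, brings in this assay a 2.5-fold lower number from compound 2 to compound 3 (0.40 log units; beyond the scatter). The step is modest but beyond the scatter, so this position is not silent to substitution, and the gain can now be tied to this one change rather than inferred from compound 1, which differs from compound 2 in more than one place. Nothing in the data shown explains why the number falls with this change.

All of this rests on one pair and one group, with the three acetoxy groups of the side chain held constant, so it cannot be said whether the step would hold on another side chain. As far as these compounds go, whether a methoxy or a benzoyloxy on the same ring carbon would move the number in the same direction, or by a similar amount, remains open.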